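A few compounds are considered here, and "the series" means these few. Any claim that something is new, unique, unknown or untested is made for them only; others in the source may bear on it.

For the measured compounds named here, in a functional assay on MCF7 cells (Homo sapiens) for cytotoxicity, read by fluorescence, with a stated time of 72 h (on this read-out higher numbers stand for weaker inhibition and lower numbers for stronger inhibition), compound 1 `Nc1n[nH]c(N)c1/N=N/c1ccncc1` gives 4300 nM, the only actual number so far. Going by the values given here, the one other measured compound, compound 2 `Nc1nn(C(=O)c2ccc([N+](=O)[O-])cc2)c(N)c1/N=N/c1ccc(O)cc1`, is reported only as a limit, > 25000 nM. The next compound, compound 3 `Cn1nc(N)c(/N=N/c2ccncc2)c1N`, keeps the core of compound 1 and carries methyl in place of hydrogen on an aromatic nitrogen. Among the compounds with values here, no measured pair shows this change, so the expectation starts from compound 1 at 4300 nM and has no direct comparison to lean on. A small move toward weaker inhibition in this assay is expected, probably no larger than the usual scatter of repeated measurements. The estimated change is a 1.4-fold higher number from compound 1 to compound 3 (0.14 log units; within the scatter). For compound 3 the expected half-maximal inhibitory concentration is 6000 nM, with an estimated range from 1800 nM to 20000 nM.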

Compound 3, half-maximal inhibitory concentration: 37700 nM
Compound 3: the middle estimate sits 6.3-fold (0.80 log units) below what was measured; the whole stated range lies below it.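

On the aromatic nitrogen of the five-membered ring, a single methyl in place of hydrogen is not a neutral change: in this assay it gives an 8.8-fold higher number from compound 1 to compound 3 (0.94 log units; beyond the scatter). For the compounds shown here, this is the first measured step at this position, and with one carbon entering and the rest of compound 1 unchanged, it shows that this hydrogen cannot be replaced by methyl without weakening inhibition on this read-out. Compound 2, which differs in more than one place, is reported only as a limit, not a number: the limit of > 25000 nM in this assay, at which 1 of the 3 values shown sits.

On these data alone, whether the loss belongs to methyl itself or would follow any replacement of that hydrogen remains open; an ethyl group, a longer chain or an acetyl group on the same nitrogen could separate the two. The compounds shown also do not tell why the number rises.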